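This account rests on a few compounds, and the source may have more. Where it says the series, first, only, none or still open, it means among the compounds named here.

Three analogues of the shared core have been measured in an assay for inhibition of MAP kinase-interacting serine/threonine-protein kinase 1 (Homo sapiens), read by luminescence and ADP-Glo, with a stated time of 2 h; on this read-out higher numbers stand for weaker inhibition and lower numbers for stronger inhibition. Compound 1 `Nc1cccc(Cn2cc(-c3ccc4cn[nH]c4c3)ccc2=O)c1` gives 287 nM; compound 2 `O=c1ccc(-c2ccc3cn[nH]c3c2)cn1Cc1ccccc1` gives 315 nM; compound 3 `O=c1ccc(-c2ccc3cn[nH]c3c2)cn1Cc1cccc(F)c1` gives 74 nM, the lowest number of the three, the steps to it being a 3.9-fold lower number from compound 1 to compound 3 (0.59 log units; beyond the scatter) and a 4.3-fold lower number from compound 2 to compound 3 (0.63 log units; beyond the scatter). Compound 4 `O=c1ccc(-c2ccc3cn[nH]c3c2)cn1Cc1ccccc1F` differs from compound 3 by 2-fluorophenyl in place of 3-fluorophenyl on a saturated chain carbon bound to an aromatic nitrogen. Going by the values given here, no measured pair shows a fluorine moved within the ring; the only fluorine steps are a 4.3-fold lower number from compound 2 to compound 3 (0.63 log units; beyond the scatter) and a 3.9-fold lower number from compound 1 to compound 3 (0.59 log units; beyond the scatter), both modest gains over the unsubstituted or amino-bearing ring. Some of that gain may not carry over when the fluorine changes place. Compound 4 is therefore expected to give a somewhat higher number, a 2.0-fold higher number from compound 3 to compound 4 (0.31 log units; beyond the scatter), of uncertain size. The estimate for compound 4 in this assay is 150 nM, range 50 nM to 450 nM.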

Compound 4, half-maximal inhibitory concentration: 47 nM
For compound 4 the middle estimate is 3.2-fold (0.50 log units) above the measured one, outside the stated range (below it).
By their numbers in this assay, from the lowest: compounds 4 and 3 (each within the scatter of the next); then compounds 1 and 2 (each within the scatter of the next).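

Moving the fluorine, 2-fluorophenyl in place of 3-fluorophenyl on a saturated chain carbon bound to an aromatic nitrogen, gives no separable change in this assay, with a 1.6-fold lower number from compound 3 to compound 4 (0.20 log units; within the scatter) and compounds 3 and 4 standing level. The fluorine gain therefore holds at both places shown: a 6.7-fold lower number from compound 2 to compound 4 (0.83 log units; beyond the scatter) against the unsubstituted ring and a 6.1-fold lower number from compound 1 to compound 4 (0.79 log units; beyond the scatter) against the amino-bearing ring are both beyond the scatter. No evidence here bears on this result.

Open: whether chloro, methoxy or nitrile can replace the fluorine, and whether a longer chain can replace the saturated chain carbon.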